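A few compounds are considered here, and "the series" means these few. Any claim that something is new, unique, unknown or untested is made for them only; others in the source may bear on it.

Three disulfide compounds sharing one core have been examined in a physicochemical assay for pharmacokinetics, at pH 7.2; on this read-out higher numbers stand for a longer-lived compound and lower numbers for a shorter-lived compound. Among the measured compounds shown here, compound 1 `CSS[C@H]1C[C@H](n2ccc(N)nc2=O)O[C@@H]1CO` is the first of them. In this assay compound 1 gives < 0.0834 h, which is a limit of the assay rather than a number. Compound 2 `Cc1cn([C@H]2C[C@H](SSc3ccc([N+](=O)[O-])cc3)[C@@H](CO)O2)c(=O)[nH]c1=O` is the second. In this assay compound 2 gives < 0.0834 h, again a limit. Compound 3 `C=CCSS[C@H]1C[C@H](n2cc(C)c(=O)[nH]c2=O)O[C@@H]1CO` is the third. In this assay compound 3 gives < 0.0834 h, also a limit, so compound 3 stands at the same limit as the other two. For the measured compounds named here, the step that the two limits leave unreadable from compound 2 to compound 3 cannot be read because the limit of < 0.0834 h in this assay, at which 3 of the 3 values shown sit, covers every value so far. Compound 4 `CCCCCCSS[C@H]1C[C@H](n2cc(C)c(=O)[nH]c2=O)O[C@@H]1CO` differs from compound 3 by pentyl in place of vinyl on a saturated chain carbon bound to a sulfur. Going by the values given here, no measured step in this assay has risen clear of that limit, so a value at the limit is expected for compound 4 as well, with the step that the limit leaves unreadable from compound 3 to compound 4 expected to be small. The estimate for compound 4 in this assay is 0.05 h, within a range from 0.01 h to 0.25 h.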

Compound 4, half-life: < 0.0834 h
Compound 4: no number, only a limit; the forecaster's own chance of this, stated with the estimate: 80%; the middle value does not contradict the limit.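

In this assay, neither the step from compound 3 to compound 4 nor the step from compound 2 to compound 4 can be read: the limit of < 0.0834 h in this assay, at which 4 of the 4 values shown sit.

The compounds shown leave open how long each one actually lasts, and so whether the group on the sulfur changes that time at all.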